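Methyl to hydrogen on the enone chain of compound 2

The source may report more compounds than this note shows. Statements on the series, on what has been measured and on what is new or still open speak of the compounds shown alone.

Of the compounds shown here, two have been tested so far in an assay on HL-60 cells for inhibition of glutathione S-transferase P (Homo sapiens), read by spectrophotometry, tested at 5 uM; a lower number here means less inhibition, a higher number more inhibition at the concentration tested (going by the name of the read-out). Compound 1, `C=C(C)C(=O)c1ccc(OCc2nc(-c3ccccc3)cs2)c(C)c1C`, gives 100% in this assay. Compound 2, `C=C(CC)C(=O)c1ccc(OCc2nc(-c3ccc([N+](=O)[O-])cc3)cs2)c(C)c1C`, gives 4.4% in this assay, the lower of the two numbers, and its distance from compound 1 lies beyond the scatter. Compound 1 and compound 2 differ in two places at once, so the two values alone cannot be split between those places.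

Compound 3, `C=C(C)C(=O)c1ccc(OCc2nc(-c3ccc([N+](=O)[O-])cc3)cs2)c(C)c1C`, has not yet been measured. It differs from compound 2 by hydrogen in place of methyl on a saturated chain carbon bound to a double-bonded chain carbon, which brings the chain of compound 3 back to the chain of compound 1.

Among the compounds with values here, with no single-place step among the measured compounds to draw on, an upward step is expected in this assay, but of uncertain size; the estimated step is a number 35.6 percentage points higher from compound 2 to compound 3 (beyond the scatter). Compound 3 is accordingly expected to give about 40% in this assay, within a wide range from 5% to 95%.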

Compound 3, a percentage reported as inhibition, at one concentration (the size of the read-out at that concentration, not a potency): 17.2%
The estimate for compound 3 lay 22.8 percentage points above the measured number, within the range that was stated.
By their numbers in this assay, from the lowest: compound 2; then compound 3; then compound 1.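

Hydrogen in place of methyl on a saturated chain carbon bound to a double-bonded chain carbon, the same difference as ethyl to methyl, gives a number 12.8 percentage points higher from compound 2 to compound 3 (beyond the scatter) in this assay, so this position does bear on the read-out, though only modestly. Nitro in place of hydrogen on an aromatic carbon gives a number 82.8 percentage points lower from compound 1 to compound 3 (beyond the scatter), a large step, so the two changes that compound 1 and compound 2 carry together can now be read one at a time, and the nitro change is the large one. Nothing available explains either step.

The compounds shown leave open whether the chain step keeps its size with hydrogen in place of nitro. They also leave open what a longer chain such as propyl at this carbon, or an amine or a carboxylic acid in place of nitro, would give.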